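One-carbon chain extension on two cores: working notes

The source may report more compounds than this note shows. Statements on the series, on what has been measured and on what is new or still open speak of the compounds shown alone.

Measured so far:
compound 1 `CCCCCCCC(=O)Nc1cccc(-c2ccccc2)c1`: -4%
compound 2 `CCCCCCCCC(=O)Nc1cccc(-c2ccccc2)c1`: -6%
compound 3 `CCCCCCCCNc1ccccc1-c1ccccc1`: -4%

In an in vitro assay on BTI-TN-5B1-4 cells for inhibition of sterol O-acyltransferase 2 (Homo sapiens), tested at 50 uM (a higher number here means more inhibition at the concentration tested (going by the name of the read-out), a lower number less inhibition), compound 1 gives -4% and compound 2 gives -6%. The two differ by methyl in place of hydrogen on a saturated chain carbon, seven bonds along the chain from a carbonyl carbon and the step of a number 2 percentage points lower from compound 1 to compound 2 (within the scatter) is small; it sits within the scatter of repeated measurements, so the longer chain on this core leaves the read-out where it was, as far as these two numbers can tell. Compound 3, on a different core, gives -4% in this assay; the difference between the core of compound 3 and the core of compound 1 is not broken down here, and the values of compound 3 and compound 1 lie within the scatter of each other.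

Compound 4 `CCCCCCCCCNc1ccccc1-c1ccccc1` has not yet been measured. It differs from compound 3 by methyl in place of hydrogen on a saturated chain carbon, eight bonds along the chain from a nitrogen on an aromatic ring. This is the same kind of change as that from compound 1 to compound 2, but the place is not the same: in the first pair the new methyl sits seven bonds along the chain from a carbonyl carbon, in the second pair eight bonds along the chain from a nitrogen on an aromatic ring. Given the small step of a number 2 percentage points lower from compound 1 to compound 2 (within the scatter) and the fact that compound 3 gives -4%, the step of a number 1 percentage points lower from compound 3 to compound 4 (within the scatter) is expected to be small as well. Compound 4 is therefore estimated at -5% in this assay, with a range of -16% to 6%.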

Compound 4, a percentage reported as inhibition, at one concentration (the size of the read-out at that concentration, not a potency): -1%
Beside the measured number, compound 4's estimate is 4 percentage points below it; low and high end bracket the measured number.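

Compound 4 gives a second reading of the same change on a different core, with the step on that core being a number 3 percentage points higher from compound 3 to compound 4 (within the scatter). Set beside the step on the core of compound 1, the two readings in this assay do not differ: the same change on two cores in this assay, a number 2 percentage points lower (within the scatter) from compound 1 to compound 2 and a number 3 percentage points higher (within the scatter) from compound 3 to compound 4, 5 percentage points apart, within the scatter of two such steps

Among the compounds shown here, as far as these four compounds go, methyl in place of hydrogen carries from one core to the other as a change that stays within the scatter on both, but this does not show that the two cores respond alike, since the new methyl sits in a different place in each pair, only one pair per core is available, and all four numbers lie close to zero, where a core-dependent step of modest size would not stand out from the scatter.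

The compounds shown leave open whether a longer chain, or a chain carrying an amine or a carboxylic acid, would move either core away from this level in this assay, and whether the same change would then still carry across. For the compounds shown here, they also leave open what separate part the linking group and the rest of each core play, as no pair here differs in one of those places alone.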